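A few compounds are considered here, and "the series" means these few. Any claim that something is new, unique, unknown or untested is made for them only; others in the source may bear on it.

In a functional assay on SiHa cells (Homo sapiens) for inhibition, read by sulforhodamine B assay (on this read-out higher numbers stand for weaker inhibition of growth and lower numbers for stronger inhibition of growth), compound 1 `c1ccc(-c2ccc(-c3ccc(-c4nc5ccccc5[nH]4)cc3)cc2)cc1` gives 100000 nM and compound 2 `Clc1cccc(-c2ccc(-c3ccc(-c4nc5ccccc5[nH]4)cc3)cc2)c1` gives 100000 nM. Compound 3 `Oc1cccc2[nH]c(-c3ccc(-c4ccc(-c5ccccc5)cc4)cc3)nc12` has the lowest number of the three, at 9710 nM. Compound 4 `Oc1cccc2[nH]c(-c3ccc(-c4ccc(-c5ccc(C(F)(F)F)cc5)cc4)cc3)nc12` keeps the hydroxy group of compound 3 and has trifluoromethyl in place of hydrogen on an aromatic carbon, para to a large group (trifluoromethyl in place of hydrogen on an aromatic carbon). Within the data shown here, no measured step tests this group. The nearest guide is the chloro replacement, which gave no change at the digits printed from compound 1 to compound 2 (within the scatter). Among the measured compounds shown here, the hydroxy replacement gave the only large change, a 10-fold lower number from compound 1 to compound 3 (1.01 log units; beyond the scatter), and compound 4 retains that hydroxy group. No change beyond the scatter is therefore expected, and the estimated step is a 1.2-fold lower number from compound 3 to compound 4 (0.08 log units; within the scatter). For compound 4 the expected value is 8000 nM, with an estimated range from 3000 nM to 25000 nM.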

Compound 4, concentration for 50% growth inhibition: 3720 nM
Compound 4: the middle estimate sits 2.2-fold (0.33 log units) above what was measured; the measured number falls inside the stated range.
By their numbers in this assay, from the lowest: compound 4; then compound 3; then compounds 1 and 2 (each within the scatter of the next).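

In this assay, trifluoromethyl in place of hydrogen on an aromatic carbon, para to a large group, gives a 2.6-fold lower number from compound 3 to compound 4 (0.42 log units; beyond the scatter). This shows that a change on this phenyl, with the hydroxy group present, can move the number beyond the scatter, unlike the chloro replacement, no change at the digits printed from compound 1 to compound 2 (within the scatter), which was read without that hydroxy group. No evidence on the cause of this step is available. On these data alone, whether trifluoromethyl would shift the number without the hydroxy group remains open. So does whether an amine or a carboxylic acid in the same place would give a similar step.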